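Bromo to furan-2-yl on the shared core

This account rests on a few compounds, and the source may have more. Where it says the series, first, only, none or still open, it means among the compounds named here.

In an assay on CHO cells for displacement of a labelled ligand from adenosine receptor A1 (Homo sapiens) (a lower number here means a stronger inhibitor, a higher number a weaker inhibitor), compound 1 `CCCn1c(Br)nc2c(N)nc(NCc3ccccc3)nc21` gives 358 nM. Among the measured compounds shown here, compound 2 `CCCn1c(Br)nc2c(N)nc(NCCCc3ccccc3)nc21` gives 583 nM in this assay, the only other number in the set, and its gap to compound 1 lies within the scatter. For the measured compounds named here, the single measured step, a 1.6-fold higher number from compound 1 to compound 2 (0.21 log units; within the scatter), alters the chain on the ring nitrogen and leaves the bromo-bearing carbon untouched. Compound 3 `CCCn1c(-c2ccco2)nc2c(N)nc(NCCCc3ccccc3)nc21` differs from compound 2 by furan-2-yl in place of bromo on an aromatic carbon. Going by the values given here, no measured step bears on this change, so no shift beyond the scatter is expected, and the estimated step is a 1.5-fold lower number from compound 2 to compound 3 (0.16 log units; within the scatter). Compound 3 is expected to give 400 nM, within 100 nM to 1600 nM.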

Compound 3, inhibition constant: 230 nM
For compound 3 the middle estimate is 1.7-fold (0.24 log units) above the measured one, within the range that was stated.
By their numbers in this assay, from the lowest: compounds 3, 1 and 2 (each within the scatter of the next, the first and the last beyond it).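

The aromatic carbon that carries bromo in compounds 1 and 2 now has its first measured change: in this assay, furan-2-yl in place of bromo gives a 2.5-fold lower number from compound 2 to compound 3 (0.40 log units; beyond the scatter). Among the compounds shown here, the earlier change on the chain stayed within the scatter, so this is the first step to exceed it. The data available offer no explanation for this shift. As far as these compounds go, whether furan-2-yl gives a similar step on the chain of compound 1 remains open. So does the result of an amine or a phenyl ring on this same aromatic carbon.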